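The compounds below may be only part of what the source reports. "The series", "measured", "known", "first", "only" and "open" are said of these compounds alone.

Compound 1 `CC(=O)Nc1cccc(Cn2cc(-c3ccc4cn[nH]c4c3)ccc2=O)c1` gives 163 nM in an assay for inhibition of MAP kinase-interacting serine/threonine-protein kinase 1 (Homo sapiens), read by luminescence and ADP-Glo, with a stated time of 2 h; on this read-out lower numbers stand for stronger inhibition and higher numbers for weaker inhibition. Compound 3 `O=c1ccc(-c2ccc3cn[nH]c3c2)cn1Cc1ccccc1`, which differs from it by hydrogen in place of acetamido on an aromatic carbon, gives 315 nM in this assay; the step of a 1.9-fold higher number from compound 1 to compound 3 (0.29 log units; within the scatter) stays within the scatter. Compound 2 `O=C(N1CCOCC1)n1cc(-c2ccc3cn[nH]c3c2)ccc1=O` reaches only a limit, > 2000 nM, in this assay. The step of an at least 6.3-fold lower number from compound 2 to compound 3 (0.80 log units; beyond the scatter) lies beyond the scatter, though it rests on (the limit of > 2000 nM in this assay, at which 1 of the 3 values shown sits). Among the two plain numbers, compound 3 holds the higher one, with compound 1 nearest and within the scatter of it; compound 2 is known only as a limit.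

Compound 4 `O=c1ccc(-c2ccc3cn[nH]c3c2)cn1Cc1cccc(Cl)c1` differs from compound 3 by chloro in place of hydrogen on an aromatic carbon. For the measured compounds named here, no measured step alters that phenyl in the same way. The nearest comparison is a 1.9-fold higher number from compound 1 to compound 3 (0.29 log units; within the scatter), a change on the same ring that stayed within the scatter. Going by the values given here, the only step beyond the scatter, an at least 6.3-fold lower number from compound 2 to compound 3 (0.80 log units; beyond the scatter), concerns the group on the aromatic nitrogen, which compound 4 keeps unchanged as benzyl. The expected step of a 1.3-fold lower number from compound 3 to compound 4 (0.10 log units; within the scatter) in this assay is therefore none beyond the scatter. Compound 4 is estimated at 250 nM, with a range from 90 nM to 700 nM.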

Compound 4, half-maximal inhibitory concentration: 37 nM
For compound 4 the middle estimate is 6.8-fold (0.83 log units) above the measured one; the measured number lies below the stated range.
By their numbers in this assay, from the lowest: compound 4; then compounds 1 and 3 (each within the scatter of the next). At a limit, above all of these: compound 2.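

In this assay, chloro in place of hydrogen on an aromatic carbon of the benzyl group, meta to a large group, gives an 8.5-fold lower number from compound 3 to compound 4 (0.93 log units; beyond the scatter), the first change on this phenyl ring shown to lie beyond the scatter. The acetamido group on the same ring had not done so, with a 1.9-fold higher number from compound 1 to compound 3 (0.29 log units; within the scatter), whereas the chloro group separates itself from acetamido with a 4.4-fold lower number from compound 1 to compound 4 (0.64 log units; beyond the scatter), so this carbon responds differently to these two groups. Replacing the group on the aromatic nitrogen gives an at least 54-fold lower number from compound 2 to compound 4 (1.73 log units; beyond the scatter), a wider step than any other here, but its size is not exact and it rests on a limit: the limit of > 2000 nM in this assay, at which 1 of the 4 values shown sits.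

The compounds shown leave open whether this effect is particular to chloro or would also appear with fluoro, bromo, methyl or methoxy on the same carbon. They also leave open what chloro does on the other carbons of the phenyl ring, and whether a second chloro group or an amine on that ring would keep the number of compound 4 in this read-out.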